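The compounds below may be only part of what the source reports. "The series", "measured", "known", "first", "only" and "open" are said of these compounds alone.

Three compounds built on one shared core were measured in an ADME assay on microsomes for inhibition of cytochrome P450 1A1 (Homo sapiens), read by fluorescence, with a stated time of 10 min; a lower number here means a stronger inhibitor, a higher number a weaker inhibitor. Compound 1 `COc1ccc(C(=O)/C=C/c2cccnc2)cc1OC` gives 3100 nM, compound 2 `O=C(/C=C/c1cccnc1)c1cccc(Cl)c1` gives 3400 nM, and compound 3 `O=C(/C=C/c1cccnc1)c1ccc(-c2ccccc2)cc1` gives 17000 nM, the highest of the three numbers; compound 2 lies nearest to it and compound 1 furthest, both gaps beyond the scatter. Compound 4 `COc1ccc(C(=O)/C=C/c2cccnc2)cc1` differs from compound 3 in one place: methoxy in place of phenyl on an aromatic carbon. Going by the values given here, no measured pair shows this exact change, so the values of compound 1 and compound 2 are the only guide. A drop toward their region is expected because compound 1 gives 3100 nM, and the step of a 3.8-fold lower number from compound 3 to compound 4 (0.58 log units; beyond the scatter) is estimated to lie beyond the scatter. For compound 4 in this assay the estimate is 4500 nM, within 1500 nM to 13000 nM.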

Compound 4, half-maximal inhibitory concentration: 3600 nM
Compound 4: middle estimate off by 1.3-fold (0.10 log units), on the high side; the measured number falls inside the stated range.
By their numbers in this assay, from the lowest: compounds 1, 2 and 4 (each within the scatter of the next); then compound 3.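

In this assay, the change on this aromatic carbon matters: methoxy in place of phenyl gives a clear step (a 4.7-fold lower number from compound 3 to compound 4 (0.67 log units; beyond the scatter)), so the phenyl of compound 3 sets it apart from compound 4. The second methoxy of compound 1 makes no difference that can be told apart (a 1.2-fold higher number from compound 1 to compound 4 (0.06 log units; within the scatter)). Nothing at hand explains either step.

Only phenyl, methoxy and hydrogen can be compared in these steps. As far as these compounds go, whether a chlorine, an amine, a carboxylic acid or a longer chain on this carbon would stay near compound 4 or move toward compound 3 remains open.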